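The compounds below may be only part of what the source reports. "The series", "measured", "known", "first", "only" and "open" are said of these compounds alone.

Measured so far in an assay for binding affinity to dual specificity mitogen-activated protein kinase kinase 4 (Homo sapiens), read by KINOMEscan, tested at 100 nM; on this read-out higher numbers stand for a weaker effect at the one concentration tested and lower numbers for a stronger effect:
compound 1 `CCCS(=O)(=O)Nc1ccc(F)c(C(=O)c2n[nH]c3ncc(-c4ccccc4Cl)cc23)c1F`, 9.3%
compound 2 `CCCS(=O)(=O)Nc1ccc(F)c(C(=O)c2n[nH]c3ncc(-c4ccc(O)cc4)cc23)c1F`, 0.75%
compound 3 `CCCS(=O)(=O)Nc1ccc(F)c(C(=O)c2n[nH]c3ncc(-c4ccccc4N)cc23)c1F`, 23%

Compound 1 stands second highest of the three values, nearest to compound 2 and furthest from compound 3. The steps from it: a number 8.6 percentage points lower from compound 1 to compound 2 (within the scatter); a number 13.7 percentage points higher from compound 1 to compound 3 (beyond the scatter). Compound 4 `CCCS(=O)(=O)Nc1ccc(F)c(C(=O)c2n[nH]c3ncc(-c4cc(Cl)cc(Cl)c4)cc23)c1F` is not yet measured and differs from compound 1 as follows: 3,5-dichlorophenyl in place of 2-chlorophenyl on an aromatic carbon. Two measured steps alter the same aryl group: a number 8.6 percentage points lower from compound 1 to compound 2 (within the scatter), and a number 22.3 percentage points higher from compound 2 to compound 3 (beyond the scatter). The step closest in kind, a number 13.7 percentage points higher from compound 1 to compound 3 (beyond the scatter), removes the chloro and is modest. Going by the values given here, no measured step adds a chlorine, so no change beyond the scatter is expected in this assay. For compound 4 the estimate is 12%, range 3% to 35%. The expected step is a number 2.7 percentage points higher from compound 1 to compound 4 (within the scatter).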

Compound 4, a percentage reported as activity, at one concentration (the size of the read-out at that concentration, not a potency): 73%
Estimate against measurement, compound 4: 61 percentage points below; the whole stated range lies below it.
By their numbers in this assay, from the lowest: compounds 2 and 1 (each within the scatter of the next); then compound 3; then compound 4.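

In this assay, going by these compounds alone, this position on the ring with one nitrogen tolerates far less change than the earlier steps suggested, all of which were within the scatter or modest: a number 63.7 percentage points higher from compound 1 to compound 4 (beyond the scatter), a number 50 percentage points higher from compound 3 to compound 4 (beyond the scatter) and a number 72.3 percentage points higher from compound 2 to compound 4 (beyond the scatter). The aryl group alone can therefore take most of the effect away, and 3,5-dichlorophenyl does so while adding only one chlorine to 2-chlorophenyl and moving the substitution. No measurement available here explains the size of these steps.

From the compounds shown here alone, it remains open whether one chlorine is enough, as 3-chlorophenyl would show. Going by these compounds, whether 3,5-dimethylphenyl or 3,5-difluorophenyl behaves the same also remains open.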